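Chain extension on the amine nitrogen of compound 2

The source may hold more compounds than are shown below. What is called first, only, known or untested is meant among the compounds shown, and "the series" means these compounds.

Measured so far:
compound 1 `NCCCc1c[nH]c2ccc(F)cc12` — 50 nM
compound 2 `CCNCCCc1c[nH]c2ccc(F)cc12` — 300 nM

In an assay on urine for inhibition of Myeloperoxidase (Homo sapiens) (a higher number here means a weaker inhibitor, a lower number a stronger inhibitor), compound 1 gives 50 nM and compound 2 gives 300 nM. Compound 2 therefore stands with the highest number of the two measured compounds, its nearest neighbour being compound 1. Among the measured compounds shown here, the one measured step, a 6.0-fold higher number from compound 1 to compound 2 (0.78 log units; beyond the scatter), is the only one that bears on what follows. Compound 3 `CCCNCCCc1c[nH]c2ccc(F)cc12` is not yet measured; it differs from compound 2 by methyl in place of hydrogen on a saturated chain carbon, two bonds along the chain from an amine nitrogen, that is, ethylamino becomes propylamino. For the measured compounds named here, no measured pair covers this place; the one known step lies on the amine nitrogen itself and is modest. A further lengthening at the same substituent is expected to move this assay a little in the same direction, or not beyond the scatter, so the step of a 1.3-fold higher number from compound 2 to compound 3 (0.12 log units; within the scatter) is estimated to be small. Compound 3 is thus expected to give 400 nM in this assay, with a range from 150 nM to 1200 nM.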

Compound 3, half-maximal inhibitory concentration: 170 nM
For compound 3 the middle estimate is 2.4-fold (0.37 log units) above the measured one, and the stated range covers the measured number.
By their numbers in this assay, from the lowest: compound 1; then compounds 3 and 2 (each within the scatter of the next).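

In this assay, ethylamino to propylamino gives a 1.8-fold lower number from compound 2 to compound 3 (0.25 log units; within the scatter) and so stays within the scatter, which shows that this chain carbon, two bonds along the chain from an amine nitrogen, tolerates the added methyl without a clear response. Propyl in place of hydrogen on the amine nitrogen gives a 3.4-fold higher number from compound 1 to compound 3 (0.53 log units; beyond the scatter) and remains beyond the scatter, so the modest step seen with ethyl as a 6.0-fold higher number from compound 1 to compound 2 (0.78 log units; beyond the scatter) is not confined to that one group. No supporting data bear on the origin of either step, and the series offers no explanation of them.

Going by these compounds, whether a butyl or longer chain would stay within the scatter of compound 3 remains open. Also open, on these data alone, is how a branched isopropyl group or a second ethyl on the amine nitrogen would compare.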